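Removing the phenyl from the ring nitrogen of compound 2

A few compounds are considered here, and "the series" means these few. Any claim that something is new, unique, unknown or untested is made for them only; others in the source may bear on it.

Two compounds have numbers in a functional assay on the whole organism (strain Charles Foster albino) for inhibition, with Rattus norvegicus as the target, read by paw edema, with stated times of 30 min and 3 h, at a dose of 50 mg/kg by the oral route; on this read-out higher numbers stand for more inhibition at the one dose given (going by the name of the read-out) and lower numbers for less inhibition. Compound 1 `COc1ccc(OC)c(C2CC(c3ccncc3)=NN2)c1` gives 13% in this assay. Within the data shown here, compound 2 `COc1ccc(OC)c(C2CC(c3cccnc3)=NN2c2ccccc2)c1` gives 24% in this assay, the higher of the two numbers; its only neighbour is compound 1, whose number lies lower by a margin beyond the usual scatter. Among the measured compounds shown here, no pair of measured compounds differs in a single place, so no single change has a measured step attached to it, and the influence of the phenyl on the ring nitrogen is not known from the data.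

Compound 3 `COc1ccc(OC)c(C2CC(c3cccnc3)=NN2)c1` is not yet measured. It differs from compound 2 by hydrogen in place of phenyl on an amine nitrogen in a ring. For the measured compounds named here, with only compound 1 at 13% as a second reference point and no matched step to lean on, the change is expected to cost some inhibition, and the step of a number 10 percentage points lower from compound 2 to compound 3 (within the scatter) is estimated as a loss of roughly the size that separates scatter from a real difference. Compound 3 is therefore estimated at 14%, within a range of 3% to 27%.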

Compound 3, a percentage reported as inhibition, in the whole organism at one dose (the size of the read-out at that dose, not a potency): 15%
Estimate against measurement, compound 3: 1 percentage points below, and the stated range covers the measured number.
By their numbers in this assay, from the lowest: compounds 1, 3 and 2 (each within the scatter of the next, the first and the last beyond it).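

In this assay, among these compounds, the step of a number 9 percentage points lower from compound 2 to compound 3 (within the scatter) is the first measured reading on the phenyl on the amine nitrogen in a ring, and at this position the two compounds cannot be told apart, so this assay shows no separable contribution from the phenyl at the one dose given. Among the compounds shown here, the step of a number 2 percentage points higher from compound 1 to compound 3 (within the scatter) is likewise the first matched reading on pyridin-3-yl in place of pyridin-4-yl on a carbon with a double bond to nitrogen, and again neither compound can be separated from the other, so neither single change on its own reaches beyond the scatter. No supporting data bear on the size of either step.

Still open, from the compounds shown here alone, is whether a different group on the same amine nitrogen, such as an acetyl or a benzyl, would give a number that stands clear of the scatter from that of compound 3 . Equally open, going by these compounds, is whether a plain phenyl on the carbon with a double bond to nitrogen, in place of pyridin-3-yl, would separate from compound 3 in this assay.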